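The source may report more compounds than this note shows. Statements on the series, on what has been measured and on what is new or still open speak of the compounds shown alone.

Measured so far in an assay on mitochondria from L6 cells (Rattus norvegicus) for activation, with a stated time of 90 min; on this read-out higher numbers stand for an effect only at larger amounts of compound and lower numbers for an effect already at smaller amounts:

- compound 1, `Oc1nc2nonc2nc1Nc1ccc(OCC2CC2)c(C(F)(F)F)c1`: 1800 nM
- compound 2, `Oc1nc2nonc2nc1Nc1ccc(SC(F)(F)F)cc1`: 1400 nM
- compound 3, `Oc1nc2nonc2nc1NCCC(F)(F)F`: 110000 nM

Compound 2 carries the lowest number of the three in this assay. Going by the values given here, compound 1 sits within the scatter of it, so no order between compound 1 and compound 2 is claimed; compound 3 sits far beyond the scatter on the high side, and the shared core with a non-aromatic chain in place of the substituted benzene is the only thing these three numbers show.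

Compound 4, `Oc1nc2nonc2nc1Nc1ccc(OC(F)(F)Cl)cc1`, has not yet been measured. It differs from compound 2 in one place:

chloro(difluoro)methoxy in place of (trifluoromethyl)sulfanyl on an aromatic carbon

Among the compounds with values here, no pair of measured compounds differs in a single place, so the size of such a step cannot be read from the numbers so far. The leaving and entering groups have the same count of heavy atoms and the same count of hydrogen-bond donors and acceptors, and the place on the ring is unchanged. On that basis the step of a 1.1-fold higher number from compound 2 to compound 4 (0.03 log units; within the scatter) is expected to stay within the scatter, with no direction favoured. Compound 4 is estimated at 1500 nM in this assay, with a range from 500 nM to 4500 nM.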

Compound 4, half-maximal effective concentration: 1900 nM
For compound 4 the middle estimate is 1.3-fold (0.10 log units) below the measured one, within the range that was stated.
By their numbers in this assay, from the lowest: compounds 2, 1 and 4 (each within the scatter of the next); then compound 3.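

Going by these compounds alone, the first single-place step is the exchange of (trifluoromethyl)sulfanyl for chloro(difluoro)methoxy on an aromatic carbon, para to a large group, and in this assay it gives (a 1.4-fold higher number from compound 2 to compound 4 (0.13 log units; within the scatter)). This position therefore accepts a group linked through oxygen and carrying chlorine in place of one linked through sulfur and carrying only fluorine, with no change that can be told from the scatter, at least for this pair of groups with equal counts of heavy atoms, hydrogen-bond donors and hydrogen-bond acceptors. No measurement shown here bears on why these two groups fall so close together.

From the compounds shown here alone, whether an amine, a carboxylic acid or a longer chain on this aromatic carbon would stay within the scatter of compound 2 remains open. Going by these compounds, it is also open whether the same exchange would give a step of similar size with another substitution pattern on the benzene ring.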